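Exchanging a halogen for a hydroxymethyl on the aryl tail

A few compounds are considered here, and "the series" means these few. Any claim that something is new, unique, unknown or untested is made for them only; others in the source may bear on it.

The two measured compounds share a core and differ only in where a bromine sits on the terminal ring. Compound 1 `O=C(CCCCCc1cccc(Br)c1)N1CCOC1=O` carries its bromo at one position; in an assay on HEK293 cells for inhibition of N-acylethanolamine-hydrolyzing acid amidase (Rattus norvegicus), read by LC-MS, with a stated time of 30 min (on this read-out higher numbers stand for weaker inhibition and lower numbers for stronger inhibition), compound 1 gives 430 nM. Compound 2 `O=C(CCCCCc1ccc(Br)cc1)N1CCOC1=O` places the bromo elsewhere on the ring, and in this assay compound 2 gives 8510 nM, the higher of the two numbers, beyond the scatter from compound 1.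

Compound 3 `O=C(CCCCCc1ccc(CO)cc1)N1CCOC1=O` is not yet measured. Relative to compound 2, the change is hydroxymethyl in place of bromo on an aromatic carbon, on an aromatic carbon of a six-membered aromatic ring of carbon only, para to a large group.

For the measured compounds named here, no measured pair tells how this exchange acts, so the expectation rests on compound 2 alone. Starting from the weak number of compound 2 at 8510 nM, the writer expects no step beyond the scatter from compound 2 to compound 3, a 1.4-fold lower number from compound 2 to compound 3 (0.15 log units; within the scatter), with either direction possible. Compound 3 is therefore estimated at 6000 nM in this assay, within a range from 1500 nM to 25000 nM.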

Compound 3, half-maximal inhibitory concentration: 190 nM
Beside the measured number, compound 3's estimate is 32-fold (1.50 log units) above it; the measured number lies below the stated range.
By their numbers in this assay, from the lowest: compound 3; then compound 1; then compound 2.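

In this assay, hydroxymethyl in place of bromo gives a 45-fold lower number from compound 2 to compound 3 (1.65 log units; beyond the scatter), a large step and the only one that can be read for this exchange. The ring position para to a large group is therefore not tied to a weak number, since compound 3 gives 190 nM with its hydroxymethyl at the same place where compound 2 gives 8510 nM with its bromo. The change adds one hydrogen-bond donor and one hydrogen-bond acceptor to the tail, but nothing shown ties the step to those counts or to any other feature of the exchange, and no measurement offers an explanation for it.

The compounds shown leave open whether the hydroxyl or the added carbon carries the step, which a methoxymethyl, an aminomethyl or a carboxylic acid at this place would begin to separate. They also leave open how hydroxymethyl behaves at the ring position that carries the bromo in compound 1, and whether a longer chain such as hydroxyethyl would hold the step at either place.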